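The source may report more compounds than this note shows. Statements on the series, on what has been measured and on what is new or still open speak of the compounds shown alone.

Measured so far:
compound 1, `COc1ccc(NCC(=O)Oc2ccc3c(C)cc(=O)oc3c2)cc1`, 37.2%
compound 2, `COc1ccccc1NCC(=O)Oc1ccc2c(C)cc(=O)oc2c1`, 26.6%
compound 3, `Cc1cc(=O)oc2cc(OC(=O)CNc3nccs3)ccc12`, 47.8%

In a functional assay on the whole organism (strain Wistar albino) for inhibition, with Rattus norvegicus as the target, read by paw edema, with stated times of 30 min and 3 h, at a dose of 20 mg/kg by the oral route (on this read-out lower numbers stand for less inhibition and higher numbers for more inhibition at the one dose given (going by the name of the read-out)), compound 3 gives the highest of the three numbers, standing above compound 1 and further above compound 2. Compound 4, `Cc1cc(=O)oc2cc(OC(=O)CNN3C=NNC3)ccc12`, differs from compound 3 by a group of 5 heavy atoms (2 carbon, 3 nitrogen; one five-membered non-aromatic ring with 3 hetero atoms) in place of a group of 5 heavy atoms (3 carbon, 1 nitrogen, 1 sulfur; one five-membered aromatic ring with 2 hetero atoms), on an amine nitrogen. Going by the values given here, no measured step swaps in a non-aromatic ring at this position; the steps that bear on it are the two earlier changes of the group on the same amine nitrogen, a number 10.6 percentage points higher from compound 1 to compound 3 (beyond the scatter) and a number 21.2 percentage points higher from compound 2 to compound 3 (beyond the scatter), both modest. A change of similar size is therefore plausible in either direction, and the expected step of a number 7.8 percentage points lower from compound 3 to compound 4 (within the scatter) carries little confidence. For compound 4 the estimate in this assay is 40%, ranging from 25% to 55%.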

Compound 4, a percentage reported as inhibition, in the whole organism at one dose (the size of the read-out at that dose, not a potency): 27.6%
Compound 4: middle estimate off by 12.4 percentage points, on the high side; measured number inside the range.
By their numbers in this assay, from the lowest: compounds 2, 4 and 1 (each within the scatter of the next, the first and the last beyond it); then compound 3.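

In this assay, the five-membered non-aromatic ring on the amine nitrogen does not hold the level of the 1,3-thiazol-2-yl group, giving a number 20.2 percentage points lower from compound 3 to compound 4 (beyond the scatter). Against the two methoxyphenyl groups it gives a number 1 percentage points higher from compound 2 to compound 4 (within the scatter) and a number 9.6 percentage points lower from compound 1 to compound 4 (within the scatter), so among the four groups shown only the 1,3-thiazol-2-yl group stands clear of all the others. Nothing measured here accounts for this step. The compounds shown leave open how a pyridin-2-yl group or a plain alkyl chain on this amine nitrogen would read.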